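Fluoro to methyl on the aryl piperazine of compound 3

The source may report more compounds than this note shows. Statements on the series, on what has been measured and on what is new or still open speak of the compounds shown alone.

Compound 3, `CCCc1nc(-c2ccccc2)c(CNCCCN2CCN(c3ccc(F)cc3)CC2)o1`, gives 62.5% in an assay on HEK293 cells for inhibition of Voltage-dependent T-type calcium channel subunit alpha-1G (Homo sapiens), read by fluorescence, tested at 10 uM (a higher number here means more inhibition at the concentration tested (going by the name of the read-out), a lower number less inhibition), the highest of the three numbers. Compound 2, `CCCc1nc(-c2ccccc2)c(CNCCN2CCN(c3ccccc3Cl)CC2)o1`, gives 60.1%, a value within the scatter of compound 3. Compound 1, `CCCc1nc(-c2ccccc2)c(CNCCN2CCN(c3ccccc3OC)CC2)o1`, gives 39.7%, clearly below compound 3. Among the measured compounds shown here, the one step measured between compounds that differ in a single place is a number 20.4 percentage points higher from compound 1 to compound 2 (beyond the scatter), a modest gain for chloro in place of methoxy on the aryl piperazine.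

Compound 4, `CCCc1nc(-c2ccccc2)c(CNCCCN2CCN(c3ccc(C)cc3)CC2)o1`, differs from compound 3 by methyl in place of fluoro on an aromatic carbon. For the measured compounds named here, no measured step covers this exchange; the chloro-for-methoxy step in this assay is the only evidence that a change on the aryl piperazine can move the number, and it sits at a different place. Going by the values given here, with that as the sole guide, compound 4 is expected to change by a number 2.5 percentage points lower from compound 3 to compound 4 (within the scatter), that is, no step beyond the scatter. Compound 4 is therefore estimated at 60%, with a range from 40% to 78%.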

Compound 4, a percentage reported as inhibition, at one concentration (the size of the read-out at that concentration, not a potency): 53.9%
Estimate against measurement, compound 4: 6.1 percentage points above, and the stated range covers the measured number.
By their numbers in this assay, from the lowest: compound 1; then compounds 4, 2 and 3 (each within the scatter of the next).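

Among the compounds shown here, exchanging fluoro for methyl, the change from 4-fluorophenyl to 4-methylphenyl, gives the first measured step at this position on the aromatic ring. In this assay it is a number 8.6 percentage points lower from compound 3 to compound 4 (within the scatter), so this exchange of one heavy atom for another does not move the number beyond the scatter. The earlier chloro-for-methoxy step did move the number beyond the scatter, but it lay at a different place and involved other groups, so it said nothing about this position.

No measurement in the data bears on why this exchange behaves as it does.

The compounds shown leave open how an amine or a carboxylic acid would read on this same aromatic carbon. They also leave open whether a larger group such as a longer alkyl chain would still stay within the scatter of compound 3.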